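Amino in place of cyano on a weakly cytotoxic scaffold

A few compounds are considered here, and "the series" means these few. Any claim that something is new, unique, unknown or untested is made for them only; others in the source may bear on it.

Compound 1 `COC(=O)c1ccc(NCc2cncn2Cc2cccc(C#N)c2)cc1-c1ccccc1` gives > 10000 nM in a toxicity assay on NIH3T3 cells (Mus musculus) for cytotoxicity, read by resazurin assay (on this read-out higher numbers stand for an effect only at larger amounts of compound and lower numbers for an effect already at smaller amounts), a limit of the assay rather than a number.
Compound 2 `N#Cc1ccc(NCc2cncn2Cc2ccc(-c3ccccc3)cc2N)cc1-c1ccccc1` gives > 1000 nM in this assay, again a limit.
Compound 3 `Fc1ccc(Cn2cncc2CNc2ccc(-c3nc4ccccc4s3)c(-c3ccccc3)c2)c(F)c1` gives > 1000 nM in this assay, also a limit.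

All three measured compounds therefore sit at limits, and compound 1 stands at the limit of > 10000 nM in this assay, at which 1 of the 3 values shown sits, while the other two sit at the limit of > 1000 nM in this assay, at which 2 of the 3 values shown sit. Within the data shown here, no numerical value is available for any of them, so no step between measured compounds can be stated; the data only show that none of the three produced an effect within the tested range.

Compound 4 `COC(=O)c1ccc(NCc2cncn2Cc2cccc(N)c2)cc1-c1ccccc1` has not yet been measured in this assay. It differs from compound 1 in a single place: amino in place of cyano on an aromatic carbon. The shared core and the remaining substituents are unchanged.

Among the measured compounds shown here, with no measured step to lean on, the only guide is the placement of all three known values at limits. The change is expected to produce no step beyond the usual scatter, so the step that the limit leaves unreadable from compound 1 to compound 4 is estimated as essentially flat. Compound 4 is accordingly expected to give about 15000 nM in this assay, with a range from 5000 nM to 50000 nM, and the most likely outcome is that the assay again reports only a limit.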

Compound 4, half-maximal effective concentration: > 10000 nM
Compound 4 gave a limit, no number; the forecaster's own chance of this, stated with the estimate: 80%; the middle value is on the limit's open side.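

In this assay compound 4 gives > 10000 nM, a limit of the assay. Among these compounds, compound 1 likewise gives a limit, > 10000 nM, so no step between compound 1 and compound 4 can be read. The compounds shown leave open at what concentration any of them would take effect, and so whether amino in place of cyano changes anything.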